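Shortening the Amine Chain: Compound 3 to Compound 4

The source may hold more compounds than are shown below. What is called first, only, known or untested is meant among the compounds shown, and "the series" means these compounds.

The measured compounds in an assay on isolated protein for binding affinity to 5-hydroxytryptamine receptor 1E (Homo sapiens); on this read-out higher numbers stand for weaker inhibition and lower numbers for stronger inhibition:
Compound 1, `COc1ccccc1-c1cc(C2CCN(C)C2)ccc1Cl`, gives 4100 nM.
Compound 2, `CCCCNCc1ccc(Cl)c(-c2ccccc2OC)c1`, gives only the assay limit of > 10000 nM, not a number.
Compound 3, `CCN(CC)Cc1ccc(Cl)c(-c2ccccc2OC)c1`, gives only the assay limit of > 10000 nM, not a number.

Compound 3 therefore stands at the edge of what this assay can report; there is no number for it, only a limit. Two of the three values sit at that limit (the limit of > 10000 nM in this assay, at which 2 of the 3 values shown sit). The step of an at least 2.4-fold higher number from compound 1 to compound 3 (0.38 log units; beyond the scatter) is at least modest, as is the step of an at least 2.4-fold higher number from compound 1 to compound 2 (0.38 log units; beyond the scatter). The step that the two limits leave unreadable from compound 2 to compound 3 cannot be read; both of its ends are limits.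

Compound 4, `CCCNCc1ccc(Cl)c(-c2ccccc2OC)c1`, differs from compound 3 by propylamino in place of diethylamino on a saturated chain carbon bound to an aromatic carbon. Among the measured compounds shown here, the only measured step in the same place, from a butylamino to a diethylamino chain, is unreadable, and compound 2, which also carries a secondary amine chain, reached only a limit. For the measured compounds named here, nothing among the measured compounds points toward a readable improvement. The expected step that the limit leaves unreadable from compound 3 to compound 4 is therefore none beyond the scatter. For compound 4 the expected reading in this assay is 15000 nM, within 5000 nM to 50000 nM, most probably again reported only as a limit.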

Compound 4, inhibition constant: > 10000 nM
Compound 4 gave a limit, no number; the forecaster's own chance of this, stated with the estimate: 75%; the middle value is on the limit's open side.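

In this assay compound 4 gives > 10000 nM, which is a limit and not a number. A propylamino chain at this place, on a saturated chain carbon bound to an aromatic carbon, therefore ends up like the butylamino chain of compound 2 and the diethylamino chain of compound 3, and the steps among these three compounds cannot be read because each of their ends is a limit: the limit of > 10000 nM in this assay, at which 3 of the 4 values shown sit.

Among the compounds shown here, the one readable step is an at least 2.4-fold higher number from compound 1 to compound 4 (0.38 log units; beyond the scatter), so all three compounds with an amine on a methyl link now stand on the weaker side of compound 1, whose 1-methylpyrrolidin-3-yl remains the only group here that yields a real number.

Going by these compounds, how far compound 2, compound 3 and compound 4 lie past the limit remains unknown, so the swap of a diethylamino group for a propylamino group, with its added hydrogen-bond donor, has no readable size in either direction. Also open, on these data alone, is whether a different amine on the same methyl link, such as a pyrrolidin-1-yl ring, a dimethylamino group or a plain primary amine, would return a number at all.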